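The source may hold more compounds than are shown below. What is called first, only, known or untested is meant among the compounds shown, and "the series" means these compounds.

Working notes on the shared core carrying an ethoxycarbonyl group and a methyl-substituted cyclic imide hydrazine. Compound 1 `CCOC(=O)c1cnc(-c2ccc(F)cc2)nc1NN1C(=O)C=C(C)C1=O` gives 700 nM in a functional assay on Jurkat cells for inhibition of nuclear factor NF-kappa-B complex (Homo sapiens); a lower number here means a stronger inhibitor, a higher number a weaker inhibitor. Compound 2 `CCOC(=O)c1cnc(-c2ccsc2)nc1NN1C(=O)C=C(C)C1=O` gives 100 nM. Compound 3 `CCOC(=O)c1cnc(-c2cc3ccccc3s2)nc1NN1C(=O)C=C(C)C1=O` gives 4000 nM, the highest of the three numbers: the step of a 5.7-fold higher number from compound 1 to compound 3 (0.76 log units; beyond the scatter) is modest, the step of a 40-fold higher number from compound 2 to compound 3 (1.60 log units; beyond the scatter) is large, so compound 3 is the weakest inhibitor measured so far.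

Compound 4 `CCOC(=O)c1cnc(Oc2ccccc2)nc1NN1C(=O)C=C(C)C1=O` differs from compound 3 by phenoxy in place of 1-benzothiophen-2-yl on an aromatic carbon. Within the data shown here, no measured step exchanges an aryl group for an aryloxy group, so the new oxygen linkage has no precedent here. What does bear on it is that the bicyclic 1-benzothiophen-2-yl group sits at the high end: both replacements by a single ring, seen backwards as a 5.7-fold higher number from compound 1 to compound 3 (0.76 log units; beyond the scatter) and a 40-fold higher number from compound 2 to compound 3 (1.60 log units; beyond the scatter), moved the number upward on arrival at compound 3, and the steps away from it were downward. A phenoxy group is again a single six-membered ring, so a downward step is expected for compound 4, estimated at a 4.0-fold lower number from compound 3 to compound 4 (0.60 log units; beyond the scatter), smaller than the large step back to compound 2 given the untested linkage. Compound 4 is therefore expected at 1000 nM in this assay, with a range of 200 nM to 5000 nM.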

Compound 4, half-maximal inhibitory concentration: 15000 nM
For compound 4 the middle estimate is 15-fold (1.18 log units) below the measured one; measured number above the stated range.
By their numbers in this assay, from the lowest: compound 2; then compound 1; then compound 3; then compound 4.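

At the position between two ring nitrogen atoms, the change to phenoxy gives a 3.8-fold higher number from compound 3 to compound 4 (0.57 log units; beyond the scatter) in this assay even though a single six-membered ring replaces the bicyclic group, so having one ring rather than two does not by itself bring the number down here. Phenoxy also compares poorly with the directly attached single rings, with a 21-fold higher number from compound 1 to compound 4 (1.33 log units; beyond the scatter) for the change from 4-fluorophenyl and a 150-fold higher number from compound 2 to compound 4 (2.18 log units; beyond the scatter) for the change from thiophen-3-yl; both steps are large and, with the step from compound 3, beyond the scatter, which leaves compound 4 as the weakest inhibitor of the four. No measurement shown gives a reason for this rise.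

The change from compound 1 to compound 4 alters both the linkage and the fluorine substituent, so a plain phenyl group at this position would be needed to separate the oxygen linkage from the loss of fluorine. The compounds shown also leave open how an anilino group, with an amine linkage, or a benzyl group, with a one-carbon linkage, would compare with phenoxy in this series.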